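The source may report more compounds than this note shows. Statements on the series, on what has been measured and on what is new or still open speak of the compounds shown alone.

Compound 3, with the structure `CC1=CC[C@H](C(C)C)c2cc(C)c(OC(=O)c3ccc(C(F)(F)F)cc3)cc21`, gives 14.7% in a functional assay on U-251 cells (Homo sapiens) for antiproliferative activity, read by sulforhodamine B assay, with a stated time of 48 h, tested at 50 uM; a higher number here means more inhibition at the concentration tested (going by the name of the read-out), a lower number less inhibition. Among the two numbers available it is the lowest: its nearest neighbour, compound 1 with the structure `CC1=CC[C@H](C(C)C)c2cc(C)c(OC(=O)c3ccc(C)cc3)cc21`, gives 67.7% in this assay. A third member of the series, compound 2 with the structure `COc1cccc(C(=O)Oc2cc3c(C)ccc(C(C)C)c3cc2C)c1`, is reported in this assay as "not active" (no number reported).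

Compound 4, with the structure `COc1ccc(C(=O)Oc2cc3c(cc2C)[C@@H](C(C)C)CC=C3C)cc1`, differs from compound 3 in one place: methoxy in place of trifluoromethyl on an aromatic carbon.

Within the data shown here, only one measured step bears on this change. The step of a number 53 percentage points lower from compound 1 to compound 3 (beyond the scatter) shows that putting trifluoromethyl in place of methyl on that aromatic carbon cost a great deal of inhibition. Compound 4 removes the trifluoromethyl again and puts in methoxy; compound 2 carries a methoxy elsewhere on the same ring and is reported as not active, so the evidence points in two directions. A partial recovery toward the number of compound 1 is expected, with a step of a number 23.3 percentage points higher from compound 3 to compound 4 (beyond the scatter) estimated for this assay. For compound 4 a value of 38% is therefore expected, within a range from 8% to 68%.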

Compound 4, a percentage reported as inhibition, at one concentration (the size of the read-out at that concentration, not a potency): 37%
Estimate against measurement, compound 4: 1 percentage points above; the measured number falls inside the stated range.
By their numbers in this assay, from the lowest: compound 3; then compound 4; then compound 1.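

Among these compounds, the earlier compounds gave only two numbers at this position, para to a large group, so methyl and trifluoromethyl could mark only a high end and a low end. In this assay methoxy in place of trifluoromethyl gives a number 22.3 percentage points higher from compound 3 to compound 4 (beyond the scatter) and methoxy in place of methyl gives a number 30.7 percentage points lower from compound 1 to compound 4 (beyond the scatter) so methoxy recovers only part of what trifluoromethyl lost. Across these three compounds the inhibition at this one position is therefore graded rather than on or off, with methyl giving the most and trifluoromethyl the least.

On these data alone, whether a chlorine atom, a hydroxyl, an amine or a longer chain such as ethoxy at this place would fit within that order remains open. Nothing measured here explains why the three groups fall in this order.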